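The source may hold more compounds than are shown below. What is called first, only, known or untested is meant among the compounds shown, and "the series" means these compounds.

Working notes on the series. Compound 1 `Cn1cc(-c2ccc(NC(=O)c3cn(CC4CCOCC4)cc(-c4ccc(F)cc4)c3=O)cc2F)c2c(N)ncnc21` gives in a functional assay on MKN-45 cells (Homo sapiens) for antiproliferative activity, with a stated time of 72 h (a lower number here means a stronger inhibitor, a higher number a weaker inhibitor), a value of 93.7 nM. Compound 2 `CN(C)C(=O)Cn1cc(C(=O)Nc2ccc(-c3cn(C)c4ncnc(N)c34)cc2)c(=O)c(-c2ccc(F)cc2)c1` has in this assay only a limit, > 100 nM, not a number; it sits at the limit of > 100 nM in this assay, at which 1 of the 2 values shown sits. Compound 3 `CC(C)n1cc(C(=O)Nc2ccc(-c3cn(C)c4ncnc(N)c34)cc2)c(=O)c(-c2ccc(F)cc2)c1` differs from compound 2 by isopropyl in place of (dimethylcarbamoyl)methyl on an aromatic nitrogen. For the measured compounds named here, no measured pair shows this change, so the expected step that the limit leaves unreadable from compound 2 to compound 3 is set near zero, with no direction claimed beyond the scatter. Compound 3 is therefore estimated at 150 nM in this assay, within 30 nM to 800 nM, with a real chance that only a limit is reported again.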

Compound 3, half-maximal inhibitory concentration: 85.3 nM
Beside the measured number, compound 3's estimate is 1.8-fold (0.25 log units) above it; measured number inside the range.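

Isopropyl in place of (dimethylcarbamoyl)methyl on the aromatic nitrogen gives, in this assay, an at least 1.1-fold lower number from compound 2 to compound 3 (0.06 log units; that floor lies within the scatter). Compound 2 has only a limit, so the true size of this step stays unread: the limit of > 100 nM in this assay, at which 1 of the 3 values shown sits. The carbonyl and nitrogen of (dimethylcarbamoyl)methyl are not required for a measured number at this position: compound 3 gives 85.3 nM.

On these data alone, how a longer alkyl chain, or a chain ending in an amine or a carboxylic acid, would read on this nitrogen stays open. A single pair cannot separate the size of the group from its atoms.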